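Taking One Methyl Off Compound 1

The source may report more compounds than this note shows. Statements on the series, on what has been measured and on what is new or still open speak of the compounds shown alone.

Of the compounds shown here, two have so far been measured in an ADME assay, in the presence of a further agent that is not named here. Compound 1 `Cc1c(Cn2ccnc2)sc2ccc(C(=O)O)cc12` gives 3.59, the lower of the two numbers, while compound 2 `Cc1c(Cn2ccnc2)n(C)c2ccc(C(=O)O)cc12` gives 4.08, and this gap lies beyond the scatter of repeated measurements.

Compound 3 `O=C(O)c1ccc2sc(Cn3ccnc3)cc2c1` has not been measured yet. It differs from compound 1 in one place: hydrogen in place of methyl on an aromatic carbon. Among the compounds with values here, no measured pair shows this change on its own, so the data offer no direct guide to its size. The starting point is therefore compound 1 at 3.59, its closest measured relative. The expected step of a number 0.01 log units higher from compound 1 to compound 3 (within the scatter) is small, with no clear direction and nothing beyond the scatter. For compound 3 the estimated value is 3.6, with an expected range from 3.2 to 4.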

Compound 3, acid dissociation constant: 3.82
Compound 3: middle estimate off by 0.22 log units, on the low side, within the range that was stated.
By their numbers in this assay, from the lowest: compounds 1, 3 and 2 (each within the scatter of the next, the first and the last beyond it).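

In this assay, hydrogen in place of methyl on this aromatic carbon of the five-membered aromatic ring, next to the ring atom that bears the (1H-imidazol-1-yl)methyl group, amounts to a number 0.23 log units higher from compound 1 to compound 3 (within the scatter). Within the data shown here, this is the first reading of this change on its own, and it shows that the methyl can be exchanged for hydrogen here without the read-out moving beyond the usual scatter, so the two compounds cannot be told apart in this assay. Nothing available accounts for the size of this step.

From the compounds shown here alone, it remains open whether a different group at this position, such as an ethyl chain, a chlorine atom or an amine, would shift the number beyond the scatter. Going by these compounds, the same exchange on the core of compound 2 also remains open, so this step cannot yet be carried over to that core.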